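The source may report more compounds than this note shows. Statements on the series, on what has been measured and on what is new or still open speak of the compounds shown alone.

Measured compounds:
- Compound 1, `Cc1ccc(-c2nc(CNc3ccc(C(=O)NO)cc3)n(-c3ccccc3)n2)cc1`, gives 62.2% in an assay on Sf9 cells for inhibition of protein deacetylase HDAC6 (Homo sapiens), read by fluorescence, with a stated time of 40 min, tested at 100 nM; a higher number here means more inhibition at the concentration tested (going by the name of the read-out), a lower number less inhibition.
- Compound 2, `COc1ccc(-c2nc(CNc3ccc(C(=O)NO)cc3)n(-c3ccccc3)n2)cc1`, gives 77.6% in this assay.

Compound 2 holds the highest of the two numbers recorded; its nearest neighbour is compound 1, and the gap between them is a number 15.4 percentage points higher from compound 1 to compound 2 (beyond the scatter), which lies beyond the scatter. Going by the values given here, that single step is the whole measured history of this series so far.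

The next compound, compound 3, `O=C(NO)c1ccc(NCc2nc(-c3cccnc3)nn2-c2ccccc2)cc1`, differs from compound 2 in one place: pyridin-3-yl in place of 4-methoxyphenyl on an aromatic carbon. Among the compounds with values here, the change sits on the same aromatic carbon that carried the methyl-to-methoxy exchange, but the group entering here, pyridin-3-yl, has no measured counterpart; the one step known, a number 15.4 percentage points higher from compound 1 to compound 2 (beyond the scatter), concerns two carbon-only rings and says nothing direct about a ring with one hetero atom. Hence no step can be anchored on precedent. With a ring of fewer heavy atoms replacing 4-methoxyphenyl, a modest loss in this assay is assumed, though a result within the scatter is equally plausible.

For compound 3 the estimate is 65%, with a range of 45% to 85%. The expected step is a number 12.6 percentage points lower from compound 2 to compound 3 (beyond the scatter).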

Compound 3, a percentage reported as inhibition, at one concentration (the size of the read-out at that concentration, not a potency): 57.7%
Beside the measured number, compound 3's estimate is 7.3 percentage points above it; measured number inside the range.
By their numbers in this assay, from the lowest: compounds 3 and 1 (each within the scatter of the next); then compound 2.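

Replacing 4-methoxyphenyl with pyridin-3-yl on the aromatic carbon between two ring nitrogen atoms gives a number 19.9 percentage points lower from compound 2 to compound 3 (beyond the scatter) in this assay, so this position responds to a change of ring as well as to a change of substituent on a carbon-only ring. Set against the 4-methylphenyl ring, the same entering group gives a number 4.5 percentage points lower from compound 1 to compound 3 (within the scatter) and so separates from compound 1 by no more than the usual scatter; among these three compounds, only compound 2 stands apart, and a six-membered aromatic ring with a hetero atom at this position still gives a number of the same order as the methyl compound. The measurements offered give no account of why the 4-methoxyphenyl ring stands apart.

Still open, going by these compounds, is whether the step seen with methoxy on a carbon-only ring would recur with a methoxy group on the pyridine ring, and whether pyridin-4-yl or pyridin-2-yl would read like pyridin-3-yl. Going by these compounds alone, also open is how a 4-aminophenyl or 4-carboxyphenyl ring, or a longer ether such as 4-ethoxyphenyl, would read at this position, and these single-concentration numbers give no potency for any compound.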